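A few compounds are considered here, and "the series" means these few. Any claim that something is new, unique, unknown or untested is made for them only; others in the source may bear on it.

Measured compounds in a functional assay (Oryctolagus cuniculus) for inhibition of platelet-activating factor receptor (Cavia porcellus); a higher number here means a weaker inhibitor, a lower number a stronger inhibitor:
compound 1 `CCCC(=O)OCC1CN(C(=O)c2cc(OC)c(OC)c(OC)c2)CCN1C(=O)c1cc(OC)c(OC)c(OC)c1` gives 420 nM
compound 2 `CCCCCCCC(=O)OCC1CN(C(=O)c2cc(OC)c(OC)c(OC)c2)CCN1C(=O)c1cc(OC)c(OC)c(OC)c1` gives 310 nM
compound 3 `CCC(CC)C(=O)OCC1CN(C(=O)c2cc(OC)c(OC)c(OC)c2)CCN1C(=O)c1cc(OC)c(OC)c(OC)c1` gives 70 nM; 40 nM; 60 nM (3 entries)

For the measured compounds named here, compound 2 is the only single-number entry besides compound 1, and the two are separated by a 1.4-fold lower number from compound 1 to compound 2 (0.13 log units; within the scatter), a butyl in place of hydrogen on the ester chain. Going by the values given here, compound 3, with the repeated entries of the several entries of compound 3 in this assay, 70 nM; 40 nM; 60 nM (3 entries), carries a branched chain at the same position; no step from compound 2 to compound 3 is computed here, so only the two sets of numbers stand side by side.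

Compound 4 `CCCCNC(=O)OCC1CN(C(=O)c2cc(OC)c(OC)c(OC)c2)CCN1C(=O)c1cc(OC)c(OC)c(OC)c1` departs from compound 2 by butylamino in place of heptyl on a carbonyl carbon, turning the ester into a carbamate. Among the compounds with values here, the only measured step in this assay, from compound 1 to compound 2, altered chain length alone and stayed within the scatter, so no measured step speaks to replacing heptyl by butylamino. On that basis the estimate for compound 4 in this assay is 300 nM, between 100 nM and 900 nM, with the step of a 1.0-fold lower number from compound 2 to compound 4 (0.01 log units; within the scatter) expected to stay within the scatter.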

Compound 4, half-maximal inhibitory concentration: 240 nM
Beside the measured number, compound 4's estimate is 1.3-fold (0.10 log units) above it, within the range that was stated.
By their numbers in this assay, from the lowest: compounds 4, 2 and 1 (each within the scatter of the next).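

In this assay, turning the ester into a carbamate at this carbonyl carbon leaves the number within the scatter of both straight-chain esters: a 1.3-fold lower number from compound 2 to compound 4 (0.11 log units; within the scatter) with butylamino in place of heptyl, and a 1.8-fold lower number from compound 1 to compound 4 (0.24 log units; within the scatter) with butylamino in place of propyl. The earlier step varied only an all-carbon chain, whereas this change brings in a nitrogen and one hydrogen-bond donor at the same place, and neither step moves beyond the scatter. No measurement given here bears on why these numbers stay so close.

Open, as far as these compounds go, is how a dimethylamino group or a longer chain such as octylamino would read on this carbonyl carbon. Also open, from the compounds shown here alone, is whether the branched chain of compound 3, at 70 nM; 40 nM; 60 nM (3 entries), would give similar numbers when carried as a carbamate.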